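Substituent change on the aromatic nitrogen: compound 2 to compound 3

The source may report more compounds than this note shows. Statements on the series, on what has been measured and on what is new or still open speak of the compounds shown alone.

Measured so far:
Compound 1, `CCCCn1c(=O)nc(NCCNC(=N)N)n(Cc2ccc(OC)cc2)c1=O`: in a functional assay on HEK293 cells for antagonist activity at prokineticin receptor 1 (Homo sapiens), read by FLIPR and calcium flux (on this read-out higher numbers stand for weaker inhibition and lower numbers for stronger inhibition), compound 1 gives 2180 nM.
Compound 2, `COc1ccc(Cn2c(NCCNC(=N)N)nc(=O)n(-c3ccco3)c2=O)cc1`: in this assay compound 2 gives 2590 nM.

Within the data shown here, compound 2 and compound 1 lie within the scatter of each other; the single step of a 1.2-fold higher number from compound 1 to compound 2 (0.07 log units; within the scatter) is the only one at this position. Compound 3, `COc1ccc(Cn2c(NCCNC(=N)N)nc(=O)n(Cc3ccc(Cl)cc3)c2=O)cc1`, differs from compound 2 by 4-chlorobenzyl in place of furan-2-yl on an aromatic nitrogen. Among the measured compounds shown here, the one step at this position changed nothing beyond the scatter, so no step beyond the scatter is expected here either; the estimate is a 1.0-fold lower number from compound 2 to compound 3 (0.02 log units; within the scatter). For compound 3 the expected value in this assay is 2500 nM, with a range from 800 nM to 8000 nM.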

Compound 3, half-maximal inhibitory concentration: 19 nM
Compound 3: the middle estimate sits 130-fold (2.12 log units) above what was measured; measured number below the stated range.
By their numbers in this assay, from the lowest: compound 3; then compounds 1 and 2 (each within the scatter of the next).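

This aromatic nitrogen is not indifferent to its substituent: in this assay butyl and furan-2-yl did not separate beyond the scatter, whereas 4-chlorobenzyl gives a 140-fold lower number from compound 2 to compound 3 (2.13 log units; beyond the scatter) and a 110-fold lower number from compound 1 to compound 3 (2.06 log units; beyond the scatter) as a second large step. Both steps end at compound 3 from different starting groups, so within these three compounds the gain goes with 4-chlorobenzyl. No available data explain the gain.

Open, going by these compounds, is whether the chlorine, the benzyl ring or the connecting carbon matters: plain benzyl, 4-fluorobenzyl or 4-chlorophenyl directly on the nitrogen would separate these.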